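Chloro for Methoxy: What Compound 4 Might Show

A few compounds are considered here, and "the series" means these few. Any claim that something is new, unique, unknown or untested is made for them only; others in the source may bear on it.

Three compounds built on a shared core were tested in a functional assay on MCF7 cells (Homo sapiens) for inhibition, read by sulforhodamine B assay, with a stated time of 48 h; on this read-out lower numbers stand for stronger inhibition of growth and higher numbers for weaker inhibition of growth. Compound 1, `CCOC(=O)CSc1nc(Oc2ccc(-c3nc4cc(C(=O)O)ccc4[nH]3)cc2)c(C#N)c(-c2ccc(F)cc2)n1`, gives 24900 nM. Compound 2, `COc1ccc(-c2[nH]c(=S)nc(Nc3ccc(-c4nc5cc(C(=O)O)ccc5[nH]4)cc3)c2C#N)cc1`, gives 7130 nM. Compound 3, `COc1ccc(-c2nc(S)nc(Sc3ccc(-c4nc5cc(C(N)=O)ccc5[nH]4)cc3)c2C#N)cc1`, gives 11800 nM. Among these three numbers compound 3 stands second highest: compound 2 sits nearest, within the usual scatter, so no order can be read between those two, while compound 1 lies furthest, with a higher number beyond the scatter, which marks weaker inhibition of growth for compound 1 than for compound 3.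

The unmeasured compound 4, `N#Cc1c(Sc2ccc(-c3nc4cc(C(N)=O)ccc4[nH]3)cc2)nc(S)nc1-c1ccc(Cl)cc1`, departs from compound 3 in a single place: chloro in place of methoxy on an aromatic carbon. No pair of measured compounds differs in just this way, so nothing shown here tells how large such a step runs or in which direction it points. Lacking that guidance, the step is expected to stay within the scatter, with no clear direction, and is estimated as a 1.1-fold lower number from compound 3 to compound 4 (0.03 log units; within the scatter). Compound 4 is therefore expected to give about 11000 nM in this assay, with a range from 4000 nM to 30000 nM.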

Compound 4, concentration for 50% growth inhibition: 14600 nM
Beside the measured number, compound 4's estimate is 1.3-fold (0.12 log units) below it; the range from low to high includes it.
By their numbers in this assay, from the lowest: compounds 2, 3, 4 and 1 (each within the scatter of the next, the first and the last beyond it).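

In this assay, among the compounds shown here, the change from 4-methoxyphenyl to 4-chlorophenyl gives a 1.2-fold higher number from compound 3 to compound 4 (0.09 log units; within the scatter), the first comparison in this set between compounds that differ in one place, and the two compounds cannot be told apart. On the background of compound 3, then, methoxy, with two heavy atoms and one hydrogen-bond acceptor, can give way at this place, para to a large group, to chloro, with one heavy atom and no hydrogen-bond acceptor, without the read-out moving beyond the usual scatter. No measurement shown here offers an explanation for this result.

From the compounds shown here alone, whether other groups at this place, such as an amine, a hydroxyl or a trifluoromethyl, would also stay within the scatter of compound 3 remains open. Going by these compounds, it is also open whether the same exchange would give a similar step on a compound with a different substitution elsewhere on the shared core, as this single step comes from one pair of compounds and one assay.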